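The source may hold more compounds than are shown below. What is called first, only, known or untested is meant among the compounds shown, and "the series" means these compounds.

Working notes on the cytotoxicity series in an ADME assay on BEAS-2B cells (Homo sapiens) for cytotoxicity, read by MTT assay, with a stated time of 72 h; a lower number here means a stronger inhibitor of growth, a higher number a weaker inhibitor of growth.

Compound 1 `CCCCCSc1nc(NCc2ccc([Se]C)cc2)c2ccccc2n1` gives 31200 nM in this assay. Compound 2 `CSc1nc(NCc2ccc([Se]C)cc2)c2ccccc2n1` gives 73500 nM. The change between them is hydrogen in place of butyl on a saturated chain carbon bound to a sulfur, and in this assay it gives a 2.4-fold higher number from compound 1 to compound 2 (0.37 log units; beyond the scatter). Within the data shown here, compound 3 `CCCCC[Se]c1nc(N)c2cccnc2n1` gives 16300 nM, the lowest of the three numbers so far; its gap to compound 1 lies within the scatter, while its gap to compound 2 lies beyond it. How the core of compound 3 differs from the core of compound 1 is not broken down here; the two differ in more than one place.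

Compound 4 `C[Se]c1nc(N)c2cccnc2n1` is not yet measured. It differs from compound 3 by hydrogen in place of butyl on a saturated chain carbon bound to a selenium atom. Among the measured compounds shown here, this is the same kind of change as the one from compound 1 to compound 2, but not the same: there the saturated chain carbon is bound to a sulfur, here it is bound to a selenium atom, and the cores also differ.

For compound 4 the step from compound 3 is expected to be a 2.2-fold higher number from compound 3 to compound 4 (0.34 log units; beyond the scatter), resting on the step from compound 1 to compound 2, a 2.4-fold higher number from compound 1 to compound 2 (0.37 log units; beyond the scatter), and on compound 3 giving 16300 nM. For the measured compounds named here, with only one earlier example, and that on a different core and a different heteroatom, the range is kept wide. Compound 4 is therefore expected to give about 36000 nM in this assay, between 17000 nM and 75000 nM.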

Compound 4, concentration for 50% growth inhibition: 39700 nM
Compound 4: the middle estimate sits 1.1-fold (0.04 log units) below what was measured; the measured number falls inside the stated range.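

In this assay, hydrogen in place of butyl on a saturated chain carbon bound to a selenium atom gives a 2.4-fold higher number from compound 3 to compound 4 (0.39 log units; beyond the scatter), and this step matches the earlier one on the other core: the same change on two cores in this assay, a 2.4-fold higher number (0.37 log units; beyond the scatter) from compound 1 to compound 2 and a 2.4-fold higher number (0.39 log units; beyond the scatter) from compound 3 to compound 4, 1.0-fold (0.01 log units) apart, within the scatter of two such steps. Within these two pairs, the drop from pentyl to methyl therefore moves the number upward by a similar amount, whether the chain is bound to a sulfur on the core of compound 1 or to a selenium atom on the core of compound 3, and neither pair goes against this. Among these compounds, the agreement rests on only two pairs, however, and the core and the heteroatom change together between them, so it does not separate the two or show that the step would hold on a third core, and it says nothing about the origin of the step.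

The compounds shown leave open how the number moves along the chain, since only pentyl and methyl appear, with nothing on ethyl, propyl or a longer chain. Also open, going by these compounds, is whether a chain ending in an amine or a carboxylic acid would follow the same step, and what swapping sulfur for selenium does on an otherwise unchanged core.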